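Swapping a fluorine for a nitrile on the pyrazole ring

The source may hold more compounds than are shown below. What is called first, only, known or untested is meant among the compounds shown, and "the series" means these compounds.

Of the compounds shown here, three sharing one core have been tested in an ADME assay on microsomes from liver (Homo sapiens) for metabolic stability; a higher number here means faster removal of the compound, a lower number slower removal. Compound 1 `CCCC(Oc1ccc(-n2cc(Cl)cn2)cc1)c1ccc(C(=O)NCCC(=O)O)cc1` gives 10 mL/min/kg. Compound 2 `CCCC(Oc1ccc(-n2cc(F)cn2)cc1)c1ccc(C(=O)NCCC(=O)O)cc1` gives 12 mL/min/kg, and the step of a 1.2-fold higher number from compound 1 to compound 2 (0.08 log units; within the scatter) is within the scatter, so these two numbers cannot be told apart. Compound 3 `O=C(O)CCNC(=O)c1ccc(C(Oc2ccc(-n3cc(C(F)(F)F)cn3)cc2)C2CC2)cc1` returns only a limit in this assay, < 8 mL/min/kg, not a number; this is the limit of < 8 mL/min/kg in this assay, at which 1 of the 3 values shown sits.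

Compound 4 `CCCC(Oc1ccc(-n2cc(C#N)cn2)cc1)c1ccc(C(=O)NCCC(=O)O)cc1` has not yet been measured. Its difference from compound 2 is cyano in place of fluoro on an aromatic carbon.

Among the compounds with values here, only one measured step touches the same ring position, the exchange of one halogen for another, and that step stayed within the scatter. Within the data shown here, an exchange of a halogen for a nitrile is a different kind of change, and no measured pair shows it, so the only guide is that this position has so far tolerated change without moving the number. The step of a 1.2-fold lower number from compound 2 to compound 4 (0.08 log units; within the scatter) is therefore expected to stay within the scatter. Compound 4 is estimated at 10 mL/min/kg, with a range from 6 mL/min/kg to 16 mL/min/kg.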

Compound 4, clearance: < 8 mL/min/kg
Compound 4: no number, only a limit (the forecaster's own chance of this, stated with the estimate: 25%); middle value at least 1.2-fold (0.09 log units) from the limit.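

In this assay compound 4 returns a limit and not a number: the limit of < 8 mL/min/kg in this assay, at which 2 of the 4 values shown sit. Until now this position had only seen one halogen exchanged for another, and the nitrile shows that a group of a different kind can sit there without raising the number, with an at least 1.5-fold lower number from compound 2 to compound 4 (0.17 log units; that floor lies within the scatter) and an at least 1.2-fold lower number from compound 1 to compound 4 (0.09 log units; that floor lies within the scatter). Both steps are only floors that lie within the scatter, so the nitrile cannot yet be told apart from fluoro or chloro, although the real steps may be larger.

The compounds shown leave open how far the number for compound 4 lies under its limit. They also leave open whether a group of another kind at this position, such as an amine or a carboxylic acid, would keep the number this low.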